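The compounds below may be only part of what the source reports. "The series", "measured", "known", "first", "only" and "open" are said of these compounds alone.

Working notes on the series. Of the compounds shown here, three of the shared core have numbers so far: compound 1 `CCc1cccc(NC(=O)CN2CCN(c3ccccn3)CC2)c1`, compound 2 `Cc1cccc(NC(=O)CCN2CCN(c3ccccn3)CC2)c1` and compound 3 `Cc1cccc(NC(=O)CN2CCN(c3ccc(Cl)cn3)CC2)c1`. In an assay on HEK293 cells for displacement of a labelled ligand from D(4) dopamine receptor (Homo sapiens), read by scintillation counting, with a stated time of 60 min (a higher number here means a weaker inhibitor, a lower number a stronger inhibitor), compound 1 gives 67.9 nM, compound 2 gives 297 nM and compound 3 gives 95 nM. On these three numbers compound 3 stands second highest; its nearest neighbour is compound 1, whose number lies within the scatter of its own, and its furthest is compound 2, whose number lies beyond the scatter.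

Compound 4 `CCc1cccc(NC(=O)CN2CCN(c3ccc(Cl)cn3)CC2)c1` has not yet been measured in this assay. It differs from compound 3 by methyl in place of hydrogen on a saturated chain carbon bound to an aromatic carbon, in words a methyl in place of hydrogen on a saturated chain carbon bound to an aromatic carbon, so that the methyl group becomes ethyl and the 3-methylphenyl becomes 3-ethylphenyl. Among the measured compounds shown here, no two measured compounds differ in one place only, so no single step of this kind has been seen. Compound 1 and compound 3 differ in two places, and their values in this assay lie within the scatter of each other.

The step from compound 3 to compound 4 is expected to be small, a 1.3-fold lower number from compound 3 to compound 4 (0.10 log units; within the scatter), not clearly beyond the scatter, leaning toward a lower number. Compound 4 is estimated at 75 nM in this assay, with a range from 35 nM to 160 nM.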

Compound 4, inhibition constant: 172 nM
Compound 4: middle estimate off by 2.3-fold (0.36 log units), on the low side, and the stated range ends below it.
By their numbers in this assay, from the lowest: compounds 1, 3, 4 and 2 (each within the scatter of the next, the first and the last beyond it).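

In this assay the series now has its first single-place steps, and methyl in place of hydrogen on a saturated chain carbon bound to an aromatic carbon, the change from 3-methylphenyl to 3-ethylphenyl, gives a 1.8-fold higher number from compound 3 to compound 4 (0.26 log units; within the scatter) in the chloro-bearing compounds. This position therefore accepts ethyl in place of methyl with no change that can be told from the scatter, at least with chloro present. Among the compounds shown here, the chloro step in the 3-ethylphenyl compounds gives a 2.5-fold higher number from compound 1 to compound 4 (0.40 log units; beyond the scatter) as a modest step, the only single-place step so far that clears the scatter, and nothing at hand accounts for either step.

Whether the chloro step carries over to the compounds with 3-methylphenyl stays open, as the shown compounds offer only the 3-ethylphenyl pair for it. Also open, on these data alone, is whether a longer chain such as propyl, or a methoxy group, at this same place would move the number beyond the scatter.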